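Replacing (pyridin-2-yl)sulfanyl with 1H-indol-1-yl in compound 3

The compounds below may be only part of what the source reports. "The series", "measured", "known", "first", "only" and "open" are said of these compounds alone.

In a functional assay on Huh-7 cells (Homo sapiens) for cytotoxicity, read by MTT assay, with a stated time of 3 days (a lower number here means that less compound is tolerated, a higher number that more compound is tolerated), compound 3 `OC[C@H]1O[C@@H](n2cnc3c(CSc4ccccn4)ncnc32)[C@H](O)[C@@H]1O` reads > 100000 nM, which is a limit and not a number. Compound 1 `OC[C@H]1O[C@@H](n2cnc3c(COc4ccccc4)ncnc32)[C@H](O)[C@@H]1O` reads > 100000 nM, also a limit. Compound 3 thus stands at the limit of > 100000 nM in this assay, at which 2 of the 3 values shown sit. Compound 2 `CN(Cc1ncnc2c1ncn2[C@@H]1O[C@H](CO)[C@@H](O)[C@H]1O)c1ccccc1` gives a true number, 21000 nM. Compound 4 `OC[C@H]1O[C@@H](n2cnc3c(Cn4ccc5ccccc54)ncnc32)[C@H](O)[C@@H]1O` changes the group on a saturated chain carbon bound to an aromatic carbon: 1H-indol-1-yl in place of (pyridin-2-yl)sulfanyl on a saturated chain carbon bound to an aromatic carbon. Among the measured compounds shown here, two measured steps bear on this change, an at least 4.7-fold lower number from compound 1 to compound 2 (0.67 log units; beyond the scatter) and an at least 4.7-fold higher number from compound 2 to compound 3 (0.67 log units; beyond the scatter). Both turn on compound 2, whose group joins through nitrogen, as the entering group does. In this assay, a modestly lower number is therefore expected, an at least 2.0-fold lower number from compound 3 to compound 4 (0.30 log units; that floor lies within the scatter). For compound 4, the estimate is 50000 nM, with an expected range from 15000 nM to 100000 nM.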

Compound 4, half-maximal cytotoxic concentration: > 250000 nM
Compound 4 was reported as a limit (the forecaster's own chance of this, stated with the estimate: 50%); middle value at least 5.0-fold (0.69 log units) from the limit.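

In this assay, joining through nitrogen at this place does not by itself bring the number down: 1H-indol-1-yl in place of methyl(phenyl)amino gives an at least 11-fold higher number from compound 2 to compound 4 (1.07 log units; beyond the scatter). Compound 4 reads as a limit and not a number: the limit of > 250000 nM in this assay, at which 1 of the 4 values shown sits. Each step to compound 4 from compound 1 and compound 3 has a limit at both ends, so these steps cannot be read.

From the compounds shown here alone, whether a morpholine or a dimethylamino group, also joined through nitrogen, would give a true number here remains open. So does any order among compound 1, compound 3 and compound 4.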